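Working notes: the step to compound 3

This account rests on a few compounds, and the source may have more. Where it says the series, first, only, none or still open, it means among the compounds named here.

Measured so far in a physicochemical assay for lipophilicity, at pH 7.4; a higher number here means a more lipophilic compound, a lower number a more polar compound (two compounds):
- compound 1 `CCc1ccc(N(Cc2ccccc2)S(=O)(=O)c2ccc3c(c2)C(=O)CC(C2CCOCC2)O3)cc1` gives 4.84
- compound 2 `CCc1ccc(N(CC(C)C)S(=O)(=O)c2ccc3c(c2)C(=O)CC(C(C)C2CCOCC2)O3)cc1` gives 4.93

Compound 2 at 4.93 lies within the scatter of compound 1 at 4.84 and the two cannot be ranked. For the measured compounds named here, they differ in more than one place, so no measured step is available to guide the next comparison.

Compound 3 `CCc1ccc(N(CC(C)C)S(=O)(=O)c2ccc3c(c2)C(=O)CC(C2CCNCC2)O3)cc1` is still unmeasured. It carries piperidin-4-yl in place of 1-(oxan-4-yl)ethyl on a saturated ring carbon and otherwise matches compound 2.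

The expectation therefore rests on the structural change alone, with compound 2 at 4.93 as the starting point. A downward move well beyond the scatter is expected, not a result indistinguishable from compound 2. Going by the values given here, the expected size is a number 2.23 log units lower from compound 2 to compound 3 (beyond the scatter) and this figure is uncertain, as no comparable step has been measured.

Compound 3 is estimated at 2.7 with an expected range from 1.9 to 3.4 in this assay pending measurement.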

Compound 3, distribution coefficient: 2.21
Beside the measured number, compound 3's estimate is 0.49 log units above it; low and high end bracket the measured number.
By their numbers in this assay, from the lowest: compound 3; then compounds 1 and 2 (each within the scatter of the next).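

In this assay the series now has its first comparison of compounds that differ in one place, on a saturated ring carbon next to the ring oxygen: a number 2.72 log units lower from compound 2 to compound 3 (beyond the scatter) with piperidin-4-yl in place of 1-(oxan-4-yl)ethyl. The number at this position therefore responds strongly to the group it carries, which compound 1 and compound 2 could not show, as they differ in more than one place. For the compounds shown here, the single step changes several things together (the ring hetero atom, the hydrogen-bond donor count and the ethyl link), and no measurement here gives a basis for assigning it to any one of them.

The compounds shown leave open how much of the step follows the ring nitrogen and how much follows the loss of the ethyl link, which 1-(piperidin-4-yl)ethyl on the otherwise unchanged structure of compound 2 would separate. Also open, on these data alone, is whether the number stays near that of compound 3 when the ring nitrogen carries a substituent, as in 1-methylpiperidin-4-yl or 1-acetylpiperidin-4-yl.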